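This account rests on a few compounds, and the source may have more. Where it says the series, first, only, none or still open, it means among the compounds named here.

Three compounds of one shared core have been examined in a functional assay on C6 cells (Rattus norvegicus) for cytotoxicity, read by MTT assay, with a stated time of 24 h, tested at 25 ug/mL; on this read-out higher numbers stand for a weaker effect at the one concentration tested and lower numbers for a stronger effect. Compound 1 `Cc1nnc(SCC(=O)N/N=c2/scc(-c3ccc(Cl)cc3)n2-c2ccccc2)s1` gives 53.3%. Compound 2 `Cc1ccc(-c2cs/c(=N/NC(=O)CSc3nnnn3-c3ccccc3)n2-c2ccccc2)cc1` gives 38.8%. Compound 3 `O=C(CSc1nnnn1-c1ccccc1)N/N=c1/scc(-c2ccc(F)cc2)n1-c1ccccc1` gives 49.3%, which places it second highest of the three, within the scatter of compound 1 and beyond the scatter above compound 2. For the measured compounds named here, the one single-point step measured so far is a number 10.5 percentage points higher from compound 2 to compound 3 (beyond the scatter), a modest move; it concerns a different exchange and so only loosely bears on what follows.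

Compound 4 `O=C(CSc1nnnn1-c1ccccc1)N/N=c1/scc(-c2ccc(Cl)cc2)n1-c1ccccc1` differs from compound 3 by chloro in place of fluoro on an aromatic carbon, a chloro entering where a fluoro leaves, on an aromatic carbon para to a large group. Going by the values given here, no measured pair isolates this exchange: compound 1 also carries chloro, but its other end differs from that of compound 3, so its value and that of compound 3 can only be read side by side, and they sit within the scatter of each other. Compound 4 is therefore expected to show no step beyond the scatter, a number 1.7 percentage points higher from compound 3 to compound 4 (within the scatter), with an estimated value of 51%, ranging from 38% to 64%.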

Compound 4, a percentage reported as activity, at one concentration (the size of the read-out at that concentration, not a potency): 62.3%
Compound 4: middle estimate off by 11.3 percentage points, on the low side; the range from low to high includes it.
By their numbers in this assay, from the lowest: compound 2; then compounds 3, 1 and 4 (each within the scatter of the next, the first and the last beyond it).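

With the 1-phenyl-1H-tetrazol-5-yl end held fixed, the 4-fluorophenyl to 4-chlorophenyl exchange on this aromatic carbon para to a large group is not silent in this assay and gives a number 13 percentage points higher from compound 3 to compound 4 (beyond the scatter) at the one concentration tested, which means a weaker effect. Chloro in place of methyl at the same carbon gives a number 23.5 percentage points higher from compound 2 to compound 4 (beyond the scatter) and is the largest step seen at this position, so methyl, fluoro and chloro are all separated there within this set. At the other end, with chloro kept, the exchange on the sulfur gives a number 9 percentage points higher from compound 1 to compound 4 (within the scatter) and so does not separate those two groups.

From the compounds shown here alone, it remains open how a bromo, a methoxy or an amine would read on this carbon, and whether the step from fluoro to chloro holds with the 5-methyl-1,3,4-thiadiazol-2-yl end on the sulfur. Nothing available explains these steps.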